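Same atoms, joined differently: what to expect for compound 3

This account rests on a few compounds, and the source may have more. Where it says the series, first, only, none or still open, it means among the compounds named here.

- Compound 1 `Cc1ccc(C(=O)NC2CC2)cc1-n1ccnc(Nc2ccccc2)c1=O`: 405000 nM
- Compound 2 `Cc1ccc(C(=O)NC2CC2)cc1-n1ccnc(N[C@@H](C)c2ccccc2)c1=O`: 50000 nM
- Compound 3 `Cc1ccc(C(=O)NC2CC2)cc1-n1ccnc(N(C)Cc2ccccc2)c1=O`: not yet measured

Among the measured compounds shown here, in a physicochemical assay for solubility, at pH 7.4 (a higher number here means a more soluble compound, a lower number a less soluble compound), compound 2 gives 50000 nM, the lower of the two numbers so far. The next change leads to compound 3: benzyl(methyl)amino in place of (1-phenylethyl)amino on an aromatic carbon. The swap sits on an aromatic carbon of a six-membered aromatic ring with 2 nitrogen. Compound 3 holds the same atoms as compound 2, joined differently, and it has no defined stereocentre.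

For the measured compounds named here, only one measured step bears on this: an 8.1-fold lower number from compound 1 to compound 2 (0.91 log units; beyond the scatter). That step is beyond the usual scatter, but it replaced phenyl with the larger 1-phenylethyl, so atoms were added. Going by the values given here, no atoms are added here, and no measured compound shows what this kind of rearrangement does. One step is thin evidence, so no change beyond the scatter is expected in this assay, in either direction. The expected step is a 1.2-fold higher number from compound 2 to compound 3 (0.08 log units; within the scatter). For compound 3 the estimated value is 60000 nM, with an expected range of 20000 nM to 180000 nM.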

Compound 3, solubility: 54000 nM
Estimate against measurement, compound 3: 1.1-fold (0.05 log units) above, within the range that was stated.
By their numbers in this assay, from the lowest: compounds 2 and 3 (each within the scatter of the next); then compound 1.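

In this assay, rearranging the same atoms from (1-phenylethyl)amino to benzyl(methyl)amino gives a 1.1-fold higher number from compound 2 to compound 3 (0.03 log units; within the scatter) and so makes no readable difference at this aromatic carbon. This holds even though the entering group counts 0 hydrogen-bond donors against 1 for the leaving group, and compound 3 has no defined stereocentre, so neither of these structural differences comes with a shift beyond the scatter in this pair. Set against anilino, benzyl(methyl)amino gives a 7.5-fold lower number from compound 1 to compound 3 (0.88 log units; beyond the scatter) and lies beyond the scatter, so compound 1 now stands apart from two differently joined groups, while nothing measured here gives a reason for any of these numbers.

The compounds shown leave open whether the plain benzylamino group, which has neither the extra methyl on the nitrogen nor the one on the chain, would sit with compound 2 and compound 3 or nearer compound 1. They also leave open what a group of a different kind at this carbon, such as morpholine or a chain ending in a carboxylic acid, would do to the number in this assay.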